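The source may report more compounds than this note shows. Statements on the series, on what has been measured and on what is new or still open speak of the compounds shown alone.

Measured compounds:
- compound 1 `O=C1NC(=O)c2c1c1c3ccccc3ccc1c1c2c2ccccc2n1[C@@H]1O[C@H](CO)[C@@H](O)[C@H](O)[C@H]1O` gives 3500 nM in a functional assay on MDA-MB-435 cells (Homo sapiens) for cytotoxicity; on this read-out higher numbers stand for weaker inhibition and lower numbers for stronger inhibition
- compound 2 `O=C1NC(=O)c2c1c1c3ccccc3ccc1c1c2c2ccccc2n1[C@@H]1O[C@H](CO)[C@@H](O)[C@H]1O` gives 3200 nM in this assay

Compound 1 holds the highest of the two numbers in this assay, with compound 2 its nearest neighbour at a 1.1-fold lower number from compound 1 to compound 2 (0.04 log units; within the scatter); the two values therefore sit within the scatter of each other and cannot be ordered. Compound 3 `O=C1NC(=O)c2c1c1c3ccccc3ccc1c1c2c2ccccc2n1[C@H]1C[C@H](O)[C@@H](CO)O1` has not yet been measured. It differs from compound 1 in one place: 4-hydroxy-5-(hydroxymethyl)oxolan-2-yl in place of 3,4,5-trihydroxy-6-(hydroxymethyl)oxan-2-yl on an aromatic nitrogen. Going by the values given here, the only measured step that bears on this is the one from compound 1 to compound 2, where the six-membered sugar was traded for a five-membered one and the number barely moved, a 1.1-fold lower number from compound 1 to compound 2 (0.04 log units; within the scatter). Compound 3 carries the same kind of exchange, with one fewer hydroxyl on the five-membered ring. Among the compounds with values here, since the one comparable step left the number essentially unchanged, no step beyond the scatter is expected in this assay for compound 3, perhaps a slight drift toward a lower number, a 1.3-fold lower number from compound 1 to compound 3 (0.13 log units; within the scatter). Compound 3 is accordingly estimated at 2600 nM, in a range of 900 nM to 8000 nM.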

Compound 3, half-maximal inhibitory concentration: 4100 nM
Compound 3: the middle estimate sits 1.6-fold (0.20 log units) below what was measured; the range from low to high includes it.
By their numbers in this assay, from the lowest: compounds 2, 1 and 3 (each within the scatter of the next).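

In this assay, going by these compounds alone, the single exchange of hydrogen in place of hydroxy on a saturated ring carbon of the five-membered sugar gives a small step (a 1.3-fold higher number from compound 2 to compound 3 (0.11 log units; within the scatter)), so this hydroxy group shows no measurable contribution to the number here. The wider exchange, 4-hydroxy-5-(hydroxymethyl)oxolan-2-yl in place of 3,4,5-trihydroxy-6-(hydroxymethyl)oxan-2-yl on an aromatic nitrogen, also stays small (a 1.2-fold higher number from compound 1 to compound 3 (0.07 log units; within the scatter)), even though the entering group has fewer heavy atoms, fewer hydrogen-bond donors, fewer hydrogen-bond acceptors and fewer defined stereocentres. Across these three sugars, ring size and hydroxy count therefore do not separate the compounds in this assay, and no available evidence explains that flat result.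

On these data alone, all three compounds carry a neutral oxygen-rich sugar on the aromatic nitrogen, so it remains open whether an amine or a carboxylic acid on that sugar would give a step beyond the scatter. As far as these compounds go, it also remains open whether a simple ethyl chain, or plain hydrogen on that nitrogen, would give a number different from those of the sugar-bearing compounds.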